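The source may hold more compounds than are shown below. What is called first, only, known or untested is meant among the compounds shown, and "the series" means these compounds.

Of the compounds shown here, three with related cores have been tested in a functional assay on HCT-116 cells (Homo sapiens) for cytotoxicity, read by MTT assay, with a stated time of 48 h, in the presence of a further agent that is not named here; a higher number here means that more compound is needed for the effect, a lower number that less compound is needed: compound 1 `Cc1nn(C)c2nc(NNC(=O)Nc3cc(Cl)nc(Cl)c3)cc(C3CC3)c12`, compound 2 `Cn1ncc2c(-c3ccc(F)cc3)cc(NNC(=O)Nc3cc(Cl)cc(Cl)c3)nc21` and compound 3 `Cn1ncc2c(-c3ccccc3)cc(NNC(=O)Nc3cc(Cl)nc(Cl)c3)nc21`. Compound 2 gives 39100 nM. This lies within the usual scatter of compound 1 at 67700 nM, so the two cannot be told apart. Compound 3 sits clearly lower at 6240 nM, meaning that less of it is needed for the effect.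

The next molecule, compound 4 `Cn1ncc2c(-c3ccc(F)cc3)cc(NNC(=O)Nc3cc(Cl)nc(OCCF)c3)nc21`, keeps the rest of compound 2 and changes one group: 2-chloro-6-(2-fluoroethoxy)pyridin-4-yl in place of 3,5-dichlorophenyl on an amide-type nitrogen. Among the measured compounds shown here, no measured pair shows this swap on its own, so any forecast is rough. Compound 1 and compound 3 also carry a six-membered aromatic ring with 1 hetero atom on that nitrogen, though they differ from compound 4 elsewhere too. They also give mixed guidance: compound 1 at 67700 nM stays level with compound 2, whereas compound 3 at 6240 nM lies lower. The expected step is a 2.0-fold lower number from compound 2 to compound 4 (0.29 log units; within the scatter), a modest move toward a lower number in this assay, and it may not clear the scatter. Compound 4 is estimated at about 20000 nM, with an expected range from 5000 nM to 80000 nM.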

Compound 4, half-maximal effective concentration: 37200 nM
Compound 4: the middle estimate sits 1.9-fold (0.27 log units) below what was measured; measured number inside the range.
By their numbers in this assay, from the lowest: compound 3; then compounds 4, 2 and 1 (each within the scatter of the next).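

In this assay, putting 2-chloro-6-(2-fluoroethoxy)pyridin-4-yl in place of 3,5-dichlorophenyl on the amide-type nitrogen gives a 1.1-fold lower number from compound 2 to compound 4 (0.02 log units; within the scatter), so the two compounds cannot be told apart. Among the compounds shown here, this is the first comparison here in which only one place differs, and it shows that this position can carry the larger group, with its hetero atom in the ring and its 2-fluoroethoxy chain, without a readable shift in the number. No measurement is available that could explain this flat result.

The swap alters the ring and its attached groups together, so the compounds shown cannot separate the contribution of the ring nitrogen from that of the 2-fluoroethoxy chain, nor say whether these changes cancel each other out. From the compounds shown here alone, it also remains open whether a different group on the same ring, such as an amine or a carboxylic acid in place of the 2-fluoroethoxy chain, would move the number beyond the scatter.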